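This account rests on a few compounds, and the source may have more. Where it says the series, first, only, none or still open, it means among the compounds named here.

Compound 1 `Cc1cc(C)cc(Cc2cc(Br)ccc2OCCn2ccc(=O)[nH]c2=O)c1` gives 1700 nM. Compound 2 `O=C(c1cc(Cl)cc(Cl)c1)c1cc(Cl)ccc1OCCn1ccc(=O)[nH]c1=O` gives 9400 nM. Compound 3 `Cc1cc(C)cc(C(=O)c2cc(C)ccc2OCCn2ccc(=O)[nH]c2=O)c1` gives 58500 nM.

In a physicochemical assay for solubility (a higher number here means a more soluble compound, a lower number a less soluble compound), compound 1 holds the lowest of the three numbers. Compound 2 sits above it by a gap beyond the scatter, and compound 3 lies furthest from compound 1, also beyond the scatter. Compound 4 `Cc1cc(C)cc(Cc2cc(C)ccc2OCCn2ccc(=O)[nH]c2=O)c1` has not yet been measured. It differs from compound 1 in one place: methyl in place of bromo on an aromatic carbon. For the measured compounds named here, no two measured compounds differ in a single place, so no measured step guides this change directly; compound 3, which carries a methyl group rather than a halogen in its core, gives the highest value but differs from compound 1 elsewhere too. A modest rise is expected: a 2.4-fold higher number from compound 1 to compound 4 (0.37 log units; beyond the scatter). Compound 4 is therefore estimated at 4000 nM, within 1500 nM to 12000 nM.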

Compound 4, solubility: 185000 nM
Estimate against measurement, compound 4: 46-fold (1.67 log units) below, and the stated range ends below it.
By their numbers in this assay, from the lowest: compound 1; then compound 2; then compound 3; then compound 4.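

In this assay the change of methyl in place of bromo on an aromatic carbon, para to a large group, gives a 110-fold higher number from compound 1 to compound 4 (2.04 log units; beyond the scatter) with nothing else in the structure altered. For the compounds shown here, it is the first single-place step available, and it shows that this position alone can carry a large change in the read-out, which compounds 1 to 3 could not separate from their other differences. Nothing at hand accounts for the size of this step.

The compounds shown leave open where fluoro, methoxy or an amine at this position would fall. They also leave open whether the same change would give a similar step in a compound with a carbonyl linker.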